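Chain-end group swaps: notes toward compound 3

The source may hold more compounds than are shown below. What is called first, only, known or untested is meant among the compounds shown, and "the series" means these compounds.

Measured compounds:
compound 1 `CCc1cc(C(C)=O)c(O)cc1OCCCCCCC#N` — 73%
compound 2 `CCc1cc(C(C)=O)c(O)cc1OCCCCCC(C)(C)c1nnn(C)n1` — 66%

In an assay on isolated protein for binding affinity to leukotriene B4 receptor 1 (Homo sapiens), tested at 1 uM (on this read-out higher numbers stand for more inhibition at the one concentration tested (going by the name of the read-out) and lower numbers for less inhibition), compound 1 gives 73% and compound 2 gives 66%. Compound 2 stands lowest of the two numbers shown, but only by a number 7 percentage points lower from compound 1 to compound 2 (within the scatter), so the two compounds cannot be ranked against each other.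

Compound 3 `CCc1cc(C(C)=O)c(O)cc1OCCCCCCS(C)(=O)=O` differs from compound 2 in one place: (methylsulfonyl)methyl in place of 1-methyl-1-(2-methyl-2H-tetrazol-5-yl)ethyl on a saturated chain carbon, five bonds along the chain from an oxygen on an aromatic ring

Among the measured compounds shown here, the single measured step bears directly on this change, since it too swaps the group at the same place on the chain while the shared core stays fixed, and it came out within the scatter. For the measured compounds named here, with one such step as the only guide, no movement beyond the scatter is expected in this assay for this further swap at the chain end.

Compound 3 is accordingly estimated at 65%, with a range from 45% to 82%. The expected step is a number 1 percentage points lower from compound 2 to compound 3 (within the scatter), judged small.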

Compound 3, a percentage reported as inhibition, at one concentration (the size of the read-out at that concentration, not a potency): 62%
Compound 3: the middle estimate sits 3 percentage points above what was measured, within the range that was stated.
By their numbers in this assay, from the lowest: compounds 3, 2 and 1 (each within the scatter of the next, the first and the last beyond it).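

In this assay, the swap at the chain end shows a number 4 percentage points lower from compound 2 to compound 3 (within the scatter), so a chain end with one five-membered aromatic ring and one with no ring cannot be ranked against each other here. Methylsulfonyl in place of cyano on a saturated chain carbon, six bonds along the chain from an oxygen on an aromatic ring, gives a number 11 percentage points lower from compound 1 to compound 3 (beyond the scatter) and is the only step among these compounds beyond the scatter, though it is modest. No measurement at hand accounts for either step.

Going by these compounds, whether a carboxylic acid or an amine at the chain end would hold the inhibition seen with the nitrile remains open. Also open, on these data alone, is how a longer chain carrying the nitrile or the methylsulfonyl group would read at this single concentration.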